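The source may report more compounds than this note shows. Statements on the series, on what has been measured and on what is new or still open speak of the compounds shown alone.

Measured so far:
- compound 1 `CC[C@H](C)[C@@H]1C(=O)N[C@H](C2Cc3ccccc3C2)C(=O)N1[C@@H](C(=O)N(C)C)c1ccc(C)[n+]([O-])c1`: 1 nM
- compound 2 `CC[C@H](C)[C@@H]1C(=O)N[C@H](C2Cc3ccccc3C2)C(=O)N1[C@@H](C(=O)NC)c1cc(C)cnc1C`: 1.26 nM

In an assay on isolated protein for displacement of a labelled ligand from Oxytocin receptor (Homo sapiens) (a lower number here means a stronger inhibitor, a higher number a weaker inhibitor), compound 1 gives 1 nM and compound 2 gives 1.26 nM; compound 2 holds the higher of the two numbers, with compound 1 its nearest neighbour, within the scatter. Compound 3 `CC[C@H](C)[C@@H]1C(=O)N[C@H](C2Cc3ccccc3C2)C(=O)N1[C@@H](C(=O)N(C)C)c1cc(C)cnc1C` is not yet measured. It differs from compound 2 by methyl in place of hydrogen on an amide-type nitrogen. Among the measured compounds shown here, no measured pair shows this change on its own, so no step size is given; the expectation is a step within the scatter in either direction, and compound 3 is expected to give 1.2 nM (range 0.5 nM to 3 nM), the expected step from compound 2 to compound 3 being a 1.1-fold lower number from compound 2 to compound 3 (0.02 log units; within the scatter).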

Compound 3, inhibition constant: 0.794 nM
For compound 3 the middle estimate is 1.5-fold (0.18 log units) above the measured one; the range from low to high includes it.
By their numbers in this assay, from the lowest: compounds 3, 1 and 2 (each within the scatter of the next).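

In this assay, methyl in place of hydrogen on the amide-type nitrogen gives a 1.6-fold lower number from compound 2 to compound 3 (0.20 log units; within the scatter), so methylcarbamoyl and dimethylcarbamoyl cannot be told apart at this position. With dimethylcarbamoyl kept, exchanging the aromatic group on the saturated chain carbon gives a 1.3-fold lower number from compound 1 to compound 3 (0.10 log units; within the scatter), so these two groups cannot be told apart either. Nothing available offers an explanation for either step.

Still open, as far as these compounds go, is whether a longer chain such as ethyl on this nitrogen stays in the same range. The same question applies to a carboxylic acid in place of the amide.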